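A few compounds are considered here, and "the series" means these few. Any claim that something is new, unique, unknown or untested is made for them only; others in the source may bear on it.

The account opens with compound 1 `C#Cc1cn([C@@H]2O[C@H](CO)[C@@H](O)[C@H]2O)c2ncnc(OC)c12`, which in an ADME assay on BJ cells (Homo sapiens), read by MTT assay, with a stated time of 72 h (on this read-out lower numbers stand for stronger inhibition and higher numbers for weaker inhibition), gives 98400 nM, the highest of the two numbers recorded there. Compound 3 `C#Cc1cn([C@@H]2O[C@H](CO)[C@@H](O)[C@H]2O)c2ncnc(N(C)C)c12` gives 410 nM in this assay. For the measured compounds named here, the one measured step between them, a 240-fold lower number from compound 1 to compound 3 (2.38 log units; beyond the scatter), is large, but it concerns a change on the six-membered ring alone. Going by the values given here, compound 2 `Nc1nc(N)c2c(-c3ccoc3)cn([C@@H]3O[C@H](CO)[C@@H](O)[C@H]3O)c2n1` reaches only a limit, > 100000 nM, in this assay; no step to it is recorded, so its value shows no more than that it is a limit (the limit of > 100000 nM in this assay, at which 1 of the 3 values shown sits). Compound 4 `COc1ncnc2c1c(-c1cc3ccccc3o1)cn2[C@@H]1O[C@H](CO)[C@@H](O)[C@H]1O` differs from compound 1 by 1-benzofuran-2-yl in place of ethynyl on an aromatic carbon. Among the compounds with values here, no measured step bears on this change, and the single known step, a 240-fold lower number from compound 1 to compound 3 (2.38 log units; beyond the scatter), sits elsewhere on the core, so its size cannot be carried over. Compound 4 is therefore expected to stay close to the weak end of the series, estimated at 40000 nM, with a range from 5000 nM to 200000 nM. For compound 4 this expectation amounts to a 2.5-fold lower number from compound 1 to compound 4 (0.39 log units; beyond the scatter), with a real chance that only a limit is reported.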

Compound 4, half-maximal inhibitory concentration: 22400 nM
The estimate for compound 4 lay 1.8-fold (0.25 log units) above the measured number, and the stated range covers the measured number.
By their numbers in this assay, from the lowest: compound 3; then compound 4; then compound 1. At a limit, above all of these: compound 2.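

In this assay, placing 1-benzofuran-2-yl on this aromatic carbon, two ring bonds from the ring nitrogen, gives a 4.4-fold lower number from compound 1 to compound 4 (0.64 log units; beyond the scatter), the first measured sign that this position affects the number. The step is modest and smaller than the one for dimethylamino in place of methoxy, a 240-fold lower number from compound 1 to compound 3 (2.38 log units; beyond the scatter), so the much larger group of 9 heavy atoms shifts the number far less than that change elsewhere on the core. Nothing given here explains why the exchange lowers the number.

The compounds shown leave open whether 1-benzofuran-2-yl would lower the number to a similar degree with dimethylamino in place of methoxy, as in compound 3. They also leave open how a plain phenyl, an amine or a carboxylic acid would fare at this position.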